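The compounds below may be only part of what the source reports. "The series", "measured", "known", "first", "only" and "open" are said of these compounds alone.

Working notes on the series, read in a functional assay on DU-145 cells (Homo sapiens) for cytotoxicity, read by ELISA, with a stated time of 2 days; a lower number here means a stronger inhibitor, a higher number a weaker inhibitor. Compound 1 `Oc1cccc(-c2cc(-c3ccccc3)cc(-c3ccccc3)n2)c1` gives 18000 nM, compound 2 `Oc1cccc(-c2cc(-c3ccccc3)cc(-c3cccs3)n2)c1` gives 18900 nM and compound 3 `Oc1cccc(-c2cc(-c3ccccc3)cc(-c3ccco3)n2)c1` gives 14400 nM. These three numbers lie within the scatter of one another, so compound 1 stands level with both of the others and no order can be drawn among them.

Compound 4 `Oc1cccc(-c2cc(-c3ccccc3)cc(-c3ccncc3)n2)c1` is still unmeasured in this assay. It keeps the core of compound 1 and changes one group: pyridin-4-yl in place of phenyl on an aromatic carbon. The replaced phenyl sits next to the ring nitrogen, and pyridin-4-yl takes its place there.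

Going by the values given here, three measured steps bear on this change. Thiophen-2-yl for the same phenyl gives a 1.1-fold higher number from compound 1 to compound 2 (0.02 log units; within the scatter), furan-2-yl for that phenyl gives a 1.3-fold lower number from compound 1 to compound 3 (0.10 log units; within the scatter), and the exchange between the two heteroaryl groups gives a 1.3-fold lower number from compound 2 to compound 3 (0.12 log units; within the scatter). All three stay within the scatter. However, no measured compound carries a pyridin-4-yl group, so this support is indirect and the range is kept wide.

No shift beyond the scatter is therefore expected, in either direction. The expected step is a 1.1-fold lower number from compound 1 to compound 4 (0.05 log units; within the scatter), which is an estimate only. For compound 4 the estimated value is 16000 nM, with an expected range of 8000 nM to 32000 nM.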

Compound 4, half-maximal inhibitory concentration: 19200 nM
Beside the measured number, compound 4's estimate is 1.2-fold (0.08 log units) below it, and the stated range covers the measured number.
By their numbers in this assay, from the lowest: compounds 3, 1, 2 and 4 (each within the scatter of the next).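

In this assay, pyridin-4-yl in place of phenyl gives a 1.1-fold higher number from compound 1 to compound 4 (0.03 log units; within the scatter), so the place next to the ring nitrogen now also holds a ring with 1 hetero atom in a six-membered aromatic ring and 1 hydrogen-bond acceptor, and the number stays level with that of the phenyl group. Pyridin-4-yl in place of furan-2-yl gives a 1.3-fold higher number from compound 3 to compound 4 (0.12 log units; within the scatter), and pyridin-4-yl in place of thiophen-2-yl gives a 1.0-fold higher number from compound 2 to compound 4 (0.01 log units; within the scatter), so all four aromatic groups at this place now stand within the scatter of one another, with no order among them. Nothing measured here bears on what lies behind this flat reading.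

Going by these compounds, all four groups at this place are aromatic rings, so it stays open whether a carboxylic acid, an aminomethyl group or a longer alkyl chain there would move the number beyond the scatter. On these data alone, it also stays open whether pyridin-2-yl or pyridin-3-yl would read the same as pyridin-4-yl, and whether the 3-hydroxyphenyl group tolerates exchange in the way this place does.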